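The source may hold more compounds than are shown below. What is called first, only, known or untested is meant among the compounds shown, and "the series" means these compounds.

Measured compounds in a functional assay on PC-12 cells (Rattus norvegicus) for cytotoxicity, read by MTT assay, with stated times of 3 h and 2 h, tested at 50 uM; a higher number here means a stronger effect of the compound at the concentration tested, a lower number a weaker effect:
Compound 1 `CC(=O)c1cc2ccc(OCCCn3cc(CNC(=O)CCCCC4CCSS4)nn3)cc2oc1=O`: 40.7%
Compound 2 `O=C(CCCCC1CCSS1)NCc1cn(CCCOc2ccc3cc(-c4ccc(Br)cc4)c(=O)oc3c2)nn1`: 74.7%
Compound 3 `CCOC(=O)c1cc2ccc(OCCCCCn3cc(CNC(=O)CCCCC4CCSS4)nn3)cc2oc1=O`: 40.7%

Compound 3 stands level with compound 1 at the digits printed, the two together at the bottom of the three numbers; compound 2 lies well above both. Among the compounds with values here, the one step measured, a number 34 percentage points higher from compound 1 to compound 2 (beyond the scatter), replaces a carbonyl-bearing group at the same position with a halogenated phenyl ring.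

Compound 4 `O=C(CCCCC1CCSS1)NCc1cn(CCCCCOc2ccc3cc(-c4ccc(Cl)c(Cl)c4)c(=O)oc3c2)nn1` is not yet measured. Its difference from compound 3: 3,4-dichlorophenyl in place of ethoxycarbonyl on an aromatic carbon. Within the data shown here, this change is of the same kind as the one from compound 1 to compound 2, so a large upward step is expected in this assay, about a number 31.3 percentage points higher from compound 3 to compound 4 (beyond the scatter). Compound 4 is therefore estimated at 72%, with a range from 52% to 88%.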

Compound 4, a percentage reported as activity, at one concentration (the size of the read-out at that concentration, not a potency): 66.2%
Compound 4: middle estimate off by 5.8 percentage points, on the high side, and the stated range covers the measured number.
By their numbers in this assay, from the lowest: compounds 1 and 3 (each within the scatter of the next); then compounds 4 and 2 (each within the scatter of the next).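

In this assay an aryl group in place of a carbonyl-bearing group at this aromatic carbon raises the number a second time (a number 25.5 percentage points higher from compound 3 to compound 4 (beyond the scatter)). The upward direction therefore holds for ethoxycarbonyl leaving as well as acetyl, for 3,4-dichlorophenyl entering as well as 4-bromophenyl, and on a pentyl chain as well as a propyl chain. It remains a pattern of two steps.

Open, from the compounds shown here alone, is how an unsubstituted phenyl, an amine or a carboxylic acid at this carbon would read. No measurement at hand explains the rise.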